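A few compounds are considered here, and "the series" means these few. Any claim that something is new, unique, unknown or untested is made for them only; others in the source may bear on it.

Series measured in a functional assay on NCI-H460 cells (Homo sapiens) for inhibition, read by MTT assay, with a stated time of 24 h, tested at 100 ug/mL; a higher number here means more inhibition of growth at the concentration tested, a lower number less inhibition of growth:
compound 1 `O=C(CCCCC(S)CCS)Nc1ccc(OC(F)(F)F)cc1`: 65.1%
compound 2 `COc1ccc(NC(=O)CCCCC(S)CCS)cc1`: 23.5%

Of these two numbers, compound 2 holds the lower, at 23.5%. Going by the values given here, its only neighbour is compound 1, and the gap between them lies beyond the scatter.

The next compound is compound 3 `O=C(CCCCC(S)CCS)Nc1ccc([N+](=O)[O-])cc1`, with nitro in place of methoxy on an aromatic carbon, para to a large group: nitro in place of methoxy on an aromatic carbon.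

Among the compounds with values here, one measured step bears on this change: a number 41.6 percentage points lower from compound 1 to compound 2 (beyond the scatter). It is large and beyond the scatter, and comes with methyl in place of trifluoromethyl on an oxygen on an aromatic ring. Nitro takes no part in that step, so it offers only a weak guide to direction. Still, the one replacement measured so far for the methoxy of compound 2 reads higher, as compound 1 gives 65.1%.

An upward move in this assay is therefore expected, though one smaller than the measured step and with wide uncertainty. The expected change is a number 24.5 percentage points higher from compound 2 to compound 3 (beyond the scatter). For compound 3 the estimated value is 48%, with an expected range of 26% to 70%.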

Compound 3, percent growth inhibition at one concentration: 39.1%
Compound 3: the middle estimate sits 8.9 percentage points above what was measured, within the range that was stated.
By their numbers in this assay, from the lowest: compound 2; then compound 3; then compound 1.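

At the aromatic carbon para to a large group, a third substituent now gives a reading in this assay: nitro in place of methoxy gives a number 15.6 percentage points higher from compound 2 to compound 3 (beyond the scatter), while nitro in place of trifluoromethoxy gives a number 26 percentage points lower from compound 1 to compound 3 (beyond the scatter). This position therefore shows more than a high and a low reading, as compound 3 lies between compound 2 and compound 1, with each of its two gaps beyond the scatter. The three groups thus rank methoxy, nitro, trifluoromethoxy from the lowest reading to the highest, but no accompanying measurement gives a basis for interpreting this order.

On these data alone, whether an amine, a carboxylic acid or a plain hydrogen at this carbon would read below compound 2, above compound 1 or between them remains open. Also open, as far as these compounds go, is whether the same order would hold at other concentrations, with each group on another carbon of the ring, or with a longer chain in place of the one shared by all three compounds.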